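Replacing a Cyclopentyl Amide with an Isopropyl Sulfonamide

The compounds below may be only part of what the source reports. "The series", "measured", "known", "first", "only" and "open" are said of these compounds alone.

Compound 2 `O=C(C1CCCC1)N1CCc2nc(C#Cc3ccccc3)sc2C1` carries a cyclopentylcarbonyl group on the amine nitrogen of its shared core. In an assay on HEK293 cells for negative allosteric modulation of metabotropic glutamate receptor 5 (Homo sapiens), read by FLIPR, with a stated time of 1 h (a lower number here means a stronger inhibitor, a higher number a weaker inhibitor), compound 2 gives > 10000 nM, which is a limit of the assay and not a number. Its close relative compound 1 `O=C(C1CCC1)N1CCc2nc(C#Cc3ccccc3)sc2C1` gives 370 nM in this assay. Between the two lies an at least 27-fold higher number from compound 1 to compound 2 (1.43 log units; beyond the scatter). Within the data shown here, compound 2 is the one of the pair that sits at the limit of > 10000 nM in this assay, at which 1 of the 2 values shown sits.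

Compound 3 `CC(C)S(=O)(=O)N1CCc2nc(C#Cc3ccccc3)sc2C1` changes compound 2 in a single place: isopropylsulfonyl in place of cyclopentylcarbonyl on an amine nitrogen in a ring. Among the measured compounds shown here, only one measured step bears on this change, and that step concerned cyclopentyl in place of cyclobutyl, not a sulfonyl group; isopropylsulfonyl has not been tested here at all. Since compound 2 already stands at the limit, the value for compound 3 is expected either to remain at the limit or to come out lower. Compound 3 is estimated to give 2500 nM in this assay, somewhere between 300 nM and 10000 nM. The expected change is an at least 4.0-fold lower number from compound 2 to compound 3 (0.60 log units; beyond the scatter).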

Compound 3, half-maximal inhibitory concentration: 11 nM
Estimate against measurement, compound 3: 230-fold (2.36 log units) above; measured number outside the range, below it.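

Until now, the only variation at this amine nitrogen in a ring was the carbon ring on a carbonyl, and that small change alone cost nearly all measurable activity. Compound 3 shows that the position is not closed to other groups: with a sulfonyl link and an open-chain isopropyl, it is a stronger inhibitor than both amides in this assay, with an at least 900-fold lower number from compound 2 to compound 3 (2.95 log units; beyond the scatter) and a 34-fold lower number from compound 1 to compound 3 (1.53 log units; beyond the scatter), the second of these being a comparison of two actual numbers. The value of compound 2 is a limit of the assay and not a number: the limit of > 10000 nM in this assay, at which 1 of the 3 values shown sits.

Both steps change the link and the group attached to it at the same time, so the compounds shown cannot say how much of the difference belongs to the sulfonyl and how much to the isopropyl. An isopropylcarbonyl group would separate the two from one side and a cyclopentylsulfonyl group from the other, while a methylsulfonyl group would show how much of the carbon chain on the sulfonyl is needed.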